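Salicylanilide series: the amide methyl of compound 1

This account rests on a few compounds, and the source may have more. Where it says the series, first, only, none or still open, it means among the compounds named here.

Compound 1, `CN(C(=O)c1cc(F)ccc1O)c1ccc(C#N)cc1`, carries a methyl on the amide nitrogen and a nitrile on the aniline ring. In a functional assay on KG-1 cells (Homo sapiens) for cytotoxicity, read by luminescence and CellTiter-Glo, with a stated time of 3 days (on this read-out lower numbers stand for stronger inhibition and higher numbers for weaker inhibition), compound 1 gives only a limit, > 10000 nM, and no number. This is the limit of > 10000 nM in this assay, at which 1 of the 3 values shown sits. The two other members measured here are secondary amides: compound 2, `N#Cc1ccc(NC(=O)c2cc(Cl)ccc2O)c(Cl)c1`, gives 860 nM in this assay, and compound 3, `O=C(Nc1ccc(Cl)c(Cl)c1)c1cc(F)ccc1O`, gives 760 nM; these two values lie within the usual scatter of each other, so no order between them can be read. Among the measured compounds shown here, no pair among the measured compounds differs in a single place, so no measured step is available for the series.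

Compound 4, `N#Cc1ccc(NC(=O)c2cc(F)ccc2O)cc1`, is compound 1 with hydrogen in place of methyl on an amide-type nitrogen, that is, hydrogen in place of methyl on the amide nitrogen whose other neighbours are an aromatic carbon and a carbonyl carbon. It shares the secondary amide of compound 2 and compound 3, each of which gives a number in this assay, while compound 1 gives only a limit. The step of an at least 5.0-fold lower number from compound 1 to compound 4 (0.69 log units; beyond the scatter) is therefore expected to be large and toward stronger inhibition, well beyond the scatter, though only the limit of compound 1 anchors its starting point. In this assay compound 4 is estimated at 2000 nM, in a range from 500 nM to 8000 nM.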

Compound 4, half-maximal inhibitory concentration: 2670 nM
Compound 4: middle estimate off by 1.3-fold (0.13 log units), on the low side, within the range that was stated.
By their numbers in this assay, from the lowest: compounds 3 and 2 (each within the scatter of the next); then compound 4. At a limit, above all of these: compound 1.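

Hydrogen in place of methyl on the amide nitrogen gives the series its first single-place step: in this assay, the change brings an at least 3.7-fold lower number from compound 1 to compound 4 (0.57 log units; beyond the scatter). Among the compounds shown here, with this pair, the effect of the group on that nitrogen can be read on the shared core, apart from the other differences that separate the earlier compounds, among which no single-place pair existed. Its size remains a lower bound, as compound 1 gives > 10000 nM, which is a limit of the assay and not a number, and the step starts from that limit: the limit of > 10000 nM in this assay, at which 1 of the 4 values shown sits.

On these data alone, whether the same change carries the same weight on the cores of compound 2 and compound 3 stays open, and the true size of the step on the core of compound 4 is also unsettled. The compounds shown also leave open how the amide nitrogen tolerates anything other than hydrogen or methyl, such as an ethyl group, a longer chain, or a chain ending in an amine or a carboxylic acid.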